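The compounds below may be only part of what the source reports. "The series", "measured", "known", "first", "only" and "open" are said of these compounds alone.

In a functional assay on COLO 205 cells (Homo sapiens) for inhibition, read by MTT assay, with a stated time of 48 h (on this read-out higher numbers stand for weaker inhibition and lower numbers for stronger inhibition), compound 1 (`COc1cc(C(=O)/C=C/c2ccc(N(C)C)cc2)cc(OC)c1OC`) gives 75000 nM and compound 2 (`COc1ccc(/C=C/C(=O)c2cc(OC)c(OC)c(OC)c2)c(OC)c1`) gives 82500 nM as its value. For the measured compounds named here, these two numbers lie within the usual scatter of each other, so compound 1 stands level with the only other measured compound. Compound 3 (`COc1cc(C(=O)/C=C/c2ccc(Br)cc2)cc(OC)c1OC`) differs from compound 1 in one place, with bromo in place of dimethylamino on an aromatic carbon. That carbon is para to a large group. Going by the values given here, no measured pair shows what this swap does, so the expectation is a loose one: perhaps a slight move toward stronger inhibition, but nothing beyond the scatter. The expected change (a 1.5-fold lower number from compound 1 to compound 3 (0.18 log units; within the scatter)) is therefore small. Compound 3 is expected to give 50000 nM with an estimated range from 15000 nM to 120000 nM around that middle value.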

Compound 3, half-maximal inhibitory concentration: 22500 nM
For compound 3 the middle estimate is 2.2-fold (0.35 log units) above the measured one, within the range that was stated.
By their numbers in this assay, from the lowest: compound 3; then compounds 1 and 2 (each within the scatter of the next).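

In this assay, bromo in place of dimethylamino on this aromatic carbon, para to a large group, gives a 3.3-fold lower number from compound 1 to compound 3 (0.52 log units; beyond the scatter) and so means stronger inhibition. For the compounds shown here, the earlier compounds offered no comparison at a single place, so this is the first sign that the group on this carbon can shift the result beyond the scatter. No measurement at hand explains the shift.

The compounds shown leave open whether the gain belongs to bromo itself or simply follows from the loss of dimethylamino, a question that chloro, a nitrile or a plain hydrogen on the same carbon could help to settle. Also open, as far as these compounds go, is whether a larger step is possible here, since one swap at one position gives no trend.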